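The compounds below may be only part of what the source reports. "The series", "measured", "known", "first", "only" and "open" are said of these compounds alone.

Measured compounds: compound 1 is `Cc1ccccc1N1CCN(CCCOc2ccc3c(=O)cc(-c4ccccc4)oc3c2)CC1`, with 117 nM in a functional assay for antagonist activity at Adrenergic receptor alpha-1 (Rattus norvegicus); a lower number here means tighter binding, a higher number weaker binding; compound 2 is `O=c1cc(-c2ccc(Cl)cc2)oc2cc(OCCCN3CCN(c4ccccc4)CC3)ccc12`, with 8.47 nM; compound 3 is `Cc1ccc(N2CCN(CCCOc3ccc4c(=O)cc(-c5ccc(Cl)cc5)oc4c3)CC2)cc1`, with 8.17 nM.

Compound 3 gives the lowest of the three numbers in this assay, yet it and compound 2 lie within the scatter of each other, while compound 1 is far higher. Among the measured compounds shown here, the only single-point step measured, a 1.0-fold lower number from compound 2 to compound 3 (0.02 log units; within the scatter), is flat. Compound 4, `Cc1ccccc1N1CCN(CCCOc2ccc3c(=O)cc(-c4ccc(Cl)cc4)oc3c2)CC1`, differs from compound 3 by 2-methylphenyl in place of 4-methylphenyl on an amine nitrogen in a ring. For the measured compounds named here, no measured step isolates this change; compound 1, which also carries 2-methylphenyl, gives the weakest value, but it differs from the others in a second place too. A rise beyond the scatter is therefore expected but uncertain: compound 4 is estimated at 45 nM (range 12 nM to 180 nM), a step of a 5.5-fold higher number from compound 3 to compound 4 (0.74 log units; beyond the scatter).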

Compound 4, dissociation constant: 16.9 nM
Compound 4: the middle estimate sits 2.7-fold (0.43 log units) above what was measured; low and high end bracket the measured number.
By their numbers in this assay, from the lowest: compounds 3, 2 and 4 (each within the scatter of the next, the first and the last beyond it); then compound 1.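

In this assay, 2-methylphenyl in place of 4-methylphenyl on an amine nitrogen in a ring gives a small but real change (a 2.1-fold higher number from compound 3 to compound 4 (0.32 log units; beyond the scatter)). Against the plain phenyl of the same series, the 2-methylphenyl group is not separated (a 2.0-fold higher number from compound 2 to compound 4 (0.30 log units; within the scatter)). With 2-methylphenyl held fixed, the chloro step is the larger one (a 6.9-fold lower number from compound 1 to compound 4 (0.84 log units; beyond the scatter)), so the high number of compound 1 goes with the missing chloro rather than with the 2-methylphenyl group.

No measured evidence gives a cause for these steps. Still open, on these data alone, is whether 3-methylphenyl or 2-methoxyphenyl on that nitrogen, or a longer chain to the piperazine-bearing ring, would keep this order.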